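The source may report more compounds than this note shows. Statements on the series, on what has been measured and on what is new or still open speak of the compounds shown alone.

Measured in a physicochemical assay for solubility, in phosphate buffer, measured as kinetic solubility, at pH 7.4; on this read-out lower numbers stand for lower solubility and higher numbers for higher solubility:
- compound 1 `Cc1oc(-c2c(Cl)cccc2C(F)(F)F)nc1CN1CCC(C(=O)NCCCN2C[C@H](C)C[C@H](C)C2)CC1`: 65.1 ug/mL
- compound 2 `Cc1cccc(F)c1-c1nc(CN2CCC(C(=O)NCCCN3C[C@H](C)C[C@H](C)C3)CC2)c(C)o1`: > 72 ug/mL, a limit
- compound 3 `Cc1cccc(-c2nc(CN3CCC(C(=O)NCCCN4C[C@H](C)C[C@H](C)C4)CC3)c(C)o2)c1`: > 69 ug/mL, a limit

Compound 3 has no exact number, only the limit > 69 ug/mL. Compound 4 `Cc1ccc(-c2nc(CN3CCC(C(=O)NCCCN4C[C@H](C)C[C@H](C)C4)CC3)c(C)o2)cc1C` carries methyl in place of hydrogen on an aromatic carbon, taking 3-methylphenyl to 3,4-dimethylphenyl: methyl in place of hydrogen on an aromatic carbon.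

For the measured compounds named here, no measured step isolates this change, so the nearest evidence comes from other changes to the aryl group. These are an at least 1.0-fold higher number from compound 1 to compound 3 (0.02 log units; that floor lies within the scatter) and an at least 1.1-fold higher number from compound 1 to compound 2 (0.04 log units; that floor lies within the scatter), both floors within the scatter, while a step that the two limits leave unreadable from compound 2 to compound 3 cannot be sized. No step beyond the scatter is therefore expected in this assay, in either direction, and the estimated step is an at least 1.0-fold lower number from compound 3 to compound 4 (0.02 log units; that floor lies within the scatter). For compound 4 the expected value is 65 ug/mL, with an estimated range of 35 ug/mL to 80 ug/mL.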

Compound 4, solubility: > 71 ug/mL
Compound 4 gave a limit, no number; the forecaster's own chance of this, stated with the estimate: 55%; middle value at least 1.0-fold (0.03 log units) from the limit.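

A second methyl on the aromatic ring still left the read-out as a limit: in this assay compound 4 gives > 71 ug/mL, which is a limit. Set against the only exact value, 3,4-dimethylphenyl gives an at least 1.0-fold higher number from compound 1 to compound 4 (0.03 log units; that floor lies within the scatter). The steps to compound 4 from compound 3 and from compound 2 cannot be read, because each joins two limits: the limit of > 71 ug/mL in this assay, at which 1 of the 4 values shown sits.

On these data alone, the true size of the methyl step stays open. So does whether an amine or a methoxy group on this aromatic carbon would give an exact value.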